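Shorter dithiolane tether on a quinazoline piperazine amide

A few compounds are considered here, and "the series" means these few. Any claim that something is new, unique, unknown or untested is made for them only; others in the source may bear on it.

For the measured compounds named here, compound 2 `COc1cc2nc(N3CCN(C(=O)CC4CCSS4)CC3)nc(N)c2cc1OC` stands at the lower end of the two numbers so far: in an assay on CHO cells with Alpha-1A adrenergic receptor (Homo sapiens) as the target (on this read-out lower numbers stand for stronger inhibition and higher numbers for weaker inhibition), compound 2 gives 0.288 nM, while compound 1 `COc1cc2nc(N3CCN(C(=O)CCCCC4CCSS4)CC3)nc(N)c2cc1OC` gives 1.41 nM. Compound 3 `COc1cc2nc(N3CCN(C(=O)C4CCSS4)CC3)nc(N)c2cc1OC` takes the change one step further, with a group of 5 heavy atoms (3 carbon, 2 sulfur; one five-membered non-aromatic ring with 2 hetero atoms) in place of a group of 6 heavy atoms (4 carbon, 2 sulfur; one five-membered non-aromatic ring with 2 hetero atoms), on a carbonyl carbon. Going by the values given here, the one measured step that bears on it is a 4.9-fold lower number from compound 1 to compound 2 (0.69 log units; beyond the scatter), where removing three chain carbons helped. Since the remaining change is smaller, a modest further lowering or none beyond the scatter is expected, a 1.4-fold lower number from compound 2 to compound 3 (0.16 log units; within the scatter), so compound 3 is estimated at 0.2 nM, between 0.07 nM and 0.6 nM.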

Compound 3, inhibition constant: 0.813 nM
Compound 3: middle estimate off by 4.1-fold (0.61 log units), on the low side, outside the stated range (above it).
By their numbers in this assay, from the lowest: compound 2; then compounds 3 and 1 (each within the scatter of the next).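

In this assay shortening the tether stops helping at this position: the group of 5 heavy atoms on a carbonyl carbon gives a 2.8-fold higher number from compound 2 to compound 3 (0.45 log units; beyond the scatter) and so reverses the direction of the first shortening. The shortest and longest tethers shown cannot be told apart, with a 1.7-fold lower number from compound 1 to compound 3 (0.24 log units; within the scatter) and compound 2 alone standing lowest of the three. Nothing available accounts for this turn.

Still open, on these data alone, is whether a chain longer than that of compound 2 but shorter than that of compound 1 would hold the low number. Also open, as far as these compounds go, is whether a cyclopentyl ring or an amine in place of the sulfur ring would keep it.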